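The source may hold more compounds than are shown below. What is called first, only, known or untested is meant among the compounds shown, and "the series" means these compounds.

Measured compounds:
Compound 1, `CN(C)CCn1cnnc1-c1cc(Oc2ccc(NC(=O)N/N=C/c3c[nH]c4ccccc34)cc2F)ccn1`: in a functional assay on U-87MG ATCC cells (Homo sapiens) for cytotoxicity, read by MTT assay, with a stated time of 72 h (a lower number here means a stronger inhibitor, a higher number a weaker inhibitor), compound 1 gives 690 nM.
Compound 2, `CN(C)CCn1cnnc1-c1cc(Oc2ccc(NC(=O)N/N=C/c3ccc(O)c(O)c3)cc2F)ccn1`: compound 2 reaches only the assay limit, > 100000 nM.

For the measured compounds named here, compound 1 therefore holds the only numerical value shown; the other value is the limit of > 100000 nM in this assay, at which 1 of the 2 values shown sits. Compound 3, `CN(C)CCn1cnnc1-c1cc(Oc2ccc(NC(=O)N/N=C/c3c(O)ccc4ccccc34)cc2F)ccn1`, differs from compound 1 in one place: 2-hydroxynaphthalen-1-yl in place of 1H-indol-3-yl on a carbon with a double bond to nitrogen. Going by the values given here, the single measured step at this position, an at least 140-fold higher number from compound 1 to compound 2 (2.16 log units; beyond the scatter), ran strongly toward weaker inhibition. Since the entering group keeps two six-membered aromatic rings, a smaller loss is expected for compound 3: a 3.6-fold higher number from compound 1 to compound 3 (0.56 log units; beyond the scatter). Compound 3 is estimated at 2500 nM, within a range from 500 nM to 25000 nM.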

Compound 3, half-maximal inhibitory concentration: 620 nM
Beside the measured number, compound 3's estimate is 4.0-fold (0.61 log units) above it; the range from low to high includes it.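

Replacing 1H-indol-3-yl with 2-hydroxynaphthalen-1-yl at this carbon makes no real difference in this assay, with a 1.1-fold lower number from compound 1 to compound 3 (0.05 log units; within the scatter). The sharp loss seen with 3,4-dihydroxyphenyl therefore does not apply to every new group here, as shown by an at least 160-fold lower number from compound 2 to compound 3 (2.20 log units; beyond the scatter). The value for compound 2 is a limit of the assay, not a number: the limit of > 100000 nM in this assay, at which 1 of the 3 values shown sits.

As far as these compounds go, it remains open whether the hydroxyl of 2-hydroxynaphthalen-1-yl matters. A plain naphthalen-1-yl or an unsubstituted phenyl group at this carbon would help to settle that.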